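A Second Methyl on the Core of Compound 1

The compounds below may be only part of what the source reports. "The series", "measured", "known", "first", "only" and "open" are said of these compounds alone.

compound 1 `CCCCOC(=O)CC1c2cccc(C)c2S(=O)(=O)N1C(=O)c1ccc(C(F)(F)F)cc1` — 1310 nM
compound 2 `CCCCOC(=O)CC1c2cccc(C)c2S(=O)(=O)N1C(=O)c1ccccc1C(F)(F)F` — 1100 nM

In an assay on HEK-Blue hNOD1 cells for antagonist activity at Nucleotide-binding oligomerization domain-containing protein 1 (Homo sapiens), read by reporter gene assay, with stated times of 3 h and 20 h (on this read-out lower numbers stand for stronger inhibition and higher numbers for weaker inhibition), compound 1 gives 1310 nM and compound 2 gives 1100 nM; a 1.2-fold lower number from compound 1 to compound 2 (0.08 log units; within the scatter) lies within the scatter, so compound 1 stands alongside compound 2 rather than apart from it. Compound 3 `CCCCOC(=O)CC1c2cc(C)cc(C)c2S(=O)(=O)N1C(=O)c1ccc(C(F)(F)F)cc1` differs from compound 1 by methyl in place of hydrogen on an aromatic carbon. Within the data shown here, the only measured step concerns the aryl group on the carbonyl, not the core, so no measured step bears on this change. Compound 3 is therefore expected to show a 1.0-fold lower number from compound 1 to compound 3 (0.00 log units; within the scatter), no step beyond the scatter. In this assay compound 3 is estimated at 1300 nM, between 450 nM and 3800 nM.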

Compound 3, half-maximal inhibitory concentration: 2460 nM
Compound 3: middle estimate off by 1.9-fold (0.28 log units), on the low side; the measured number falls inside the stated range.
By their numbers in this assay, from the lowest: compounds 2, 1 and 3 (each within the scatter of the next, the first and the last beyond it).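

In this assay, among these compounds, methyl in place of hydrogen on this aromatic carbon gives a 1.9-fold higher number from compound 1 to compound 3 (0.27 log units; within the scatter) and is the first measured change on the core of compound 1. This carbon, meta to a methyl group, therefore takes an added methyl without a step that can be told from repeat measurement. No evidence is available to explain this result. The compounds shown leave open whether a methoxy group, an amine or a carboxylic acid on this carbon would stay within the scatter. They also leave open whether the added methyl would read the same with the 2-(trifluoromethyl)phenyl group of compound 2.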